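Swapping 2,3-dimethoxyphenyl for 3,4,5-trimethoxyphenyl

The source may hold more compounds than are shown below. What is called first, only, known or untested is meant among the compounds shown, and "the series" means these compounds.

Measured in an ADME assay on cells (Lymphocyte, Homo sapiens) for cytotoxicity, read by MTT assay, with a stated time of 48 h; on this read-out lower numbers stand for stronger inhibition and higher numbers for weaker inhibition:
- Compound 1 `COC(=O)/C(=C\c1ccc(OC(=O)c2cccc(OC)c2)cc1)Sc1ccnc2cc(Cl)ccc12` gives > 100000 nM, which is a limit of the assay.
- Compound 2 `COC(=O)/C(=C\c1ccc(OC(=O)c2cc(OC)cc(OC)c2)cc1)Sc1ccnc2cc(Cl)ccc12` gives 84100 nM.
- Compound 3 `COC(=O)/C(=C\c1ccc(OC(=O)c2cccc(OC)c2OC)cc1)Sc1ccnc2cc(Cl)ccc12` gives 86600 nM.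

Among the measured compounds shown here, compound 3 stands level with the only other true number in the set: a 1.0-fold higher number from compound 2 to compound 3 (0.01 log units; within the scatter). Compound 4 `COC(=O)/C(=C\c1ccc(OC(=O)c2cc(OC)c(OC)c(OC)c2)cc1)Sc1ccnc2cc(Cl)ccc12` has 3,4,5-trimethoxyphenyl in place of 2,3-dimethoxyphenyl on a carbonyl carbon. The closest measured changes are methoxy in place of hydrogen on an aromatic carbon, giving an at least 1.1-fold lower number from compound 1 to compound 2 (0.07 log units; that floor lies within the scatter) and an at least 1.1-fold lower number from compound 1 to compound 3 (0.06 log units; that floor lies within the scatter). None of these steps leaves the scatter, so no step beyond the scatter is expected in this assay. The expected change is a 1.0-fold lower number from compound 3 to compound 4 (0.01 log units; within the scatter). Compound 4 is estimated at 85000 nM, with an expected range from 50000 nM to 130000 nM.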

Compound 4, half-maximal inhibitory concentration: 35200 nM
The estimate for compound 4 lay 2.4-fold (0.38 log units) above the measured number, and the stated range ends above it.
By their numbers in this assay, from the lowest: compound 4; then compounds 2 and 3 (each within the scatter of the next). At a limit, above all of these: compound 1.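

In this assay, 3,4,5-trimethoxyphenyl on this carbonyl carbon is the only group shown that moves the number beyond the scatter, with a 2.5-fold lower number from compound 3 to compound 4 (0.39 log units; beyond the scatter) and a 2.4-fold lower number from compound 2 to compound 4 (0.38 log units; beyond the scatter), whereas the two dimethoxyphenyl compounds stand level. The step of an at least 2.8-fold lower number from compound 1 to compound 4 (0.45 log units; beyond the scatter) starts from a limit, so it gives only a floor. Adding a methoxy therefore does not read alike throughout this small set: the same change on two cores in this assay, an at least 1.1-fold lower number (0.06 log units; that floor lies within the scatter) from compound 1 to compound 3 and a 2.4-fold lower number (0.38 log units; beyond the scatter) from compound 2 to compound 4; the limit leaves it open whether they differ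

As far as these compounds go, it remains open whether the lower number belongs to the whole 3,4,5-trimethoxyphenyl group or to a single methoxy within it. From the compounds shown here alone, it also remains open how an amine or a carboxylic acid on this aromatic ring would read.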